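From methoxy to (4-fluorophenyl)amino on the shared core

A few compounds are considered here, and "the series" means these few. Any claim that something is new, unique, unknown or untested is made for them only; others in the source may bear on it.

Compound 1 `C=C[C@@](C)(/C=C/c1ccc(OC)cc1)CCC=C(C)C` has been tested in a functional assay on Raji cells (Homo sapiens) for cytotoxicity, with a stated time of 72 h (a higher number here means that more compound is needed for the effect, a lower number that less compound is needed), and gives > 26000 nM as a limit, not a number. Compound 2 `C=C[C@@](C)(/C=C/c1ccc(O)cc1)CC/C=C/C#N` gives > 26000 nM as a limit too. Compound 3 `CC(C)=CCC[C@@](C)(/C=C/c1ccc(C)cc1)/C=C/c1ccc(O)cc1` also gives > 26000 nM as a limit. Compound 1 therefore shares the limit of > 26000 nM in this assay, at which 3 of the 3 values shown sit, with the other two. Compound 4 `C=C[C@@](C)(/C=C/c1ccc(Nc2ccc(F)cc2)cc1)CCC=C(C)C` carries (4-fluorophenyl)amino in place of the methoxy of compound 1 on an aromatic carbon, para to a large group (4-fluorophenyl)amino in place of methoxy on an aromatic carbon in all. Going by the values given here, no measured step covers this change. A modest move towards less compound needed is expected, and the estimated at least 1.8-fold lower number from compound 1 to compound 4 (0.26 log units; that floor lies within the scatter) is only tentative. Compound 4 is expected at 14000 nM with an estimated range from 4000 nM to 26000 nM in this assay.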

Compound 4, half-maximal effective concentration: > 26000 nM
Compound 4: no number, only a limit; the forecaster's own chance of this, stated with the estimate: 50%; at least 1.8-fold (0.26 log units) between middle value and limit.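

Compound 1 and compound 4 each give only a limit in this assay, so no step can be read between them. The compounds shown leave open what concentration any of them needs for the effect in this assay.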